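The compounds below may be only part of what the source reports. "The series", "measured", "known", "first", "only" and "open" are said of these compounds alone.

Going by the values given here, in a functional assay on MCF7 cells (Homo sapiens) for antiproliferative activity, read by MTT assay, with a stated time of 48 h (a higher number here means a weaker inhibitor, a lower number a stronger inhibitor), compound 1 (`COc1cc(-c2nnc3c(OC4CCC4)cc(-c4ccc5[nH]ccc5c4)cn23)cc(OC)c1OC`) gives 267 nM and compound 2 (`COc1cc(-c2nnc3c(OC4CC4)cc(-c4ccc5[nH]ccc5c4)cn23)cc(OC)c1OC`) gives 259 nM so compound 2 stands level with the only other measured compound. Among the compounds with values here, the one measured step (a 1.0-fold lower number from compound 1 to compound 2 (0.01 log units; within the scatter)) puts cyclopropyl in place of cyclobutyl on an oxygen and stays within the scatter. Compound 3 (`COc1cc(-c2nnc3c(OC4CC4)cc(-c4ccc5c(ccn5C)c4)cn23)cc(OC)c1OC`) differs elsewhere (methyl in place of hydrogen on an aromatic nitrogen) with methyl in place of hydrogen on an aromatic nitrogen. Within the data shown here, no measured step covers this change, so no shift beyond the scatter is expected, though with wide uncertainty. The expected step (a 1.2-fold lower number from compound 2 to compound 3 (0.07 log units; within the scatter)) stays within the scatter. In this assay the estimate for compound 3 is 220 nM (expected range 70 nM to 700 nM).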

Compound 3, half-maximal inhibitory concentration: 118 nM
Compound 3: the middle estimate sits 1.9-fold (0.27 log units) above what was measured, within the range that was stated.
By their numbers in this assay, from the lowest: compound 3; then compounds 2 and 1 (each within the scatter of the next).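

In this assay the aromatic nitrogen of the five-membered ring is the first place shown where a change moves the number beyond the scatter: putting methyl in place of hydrogen gives a 2.2-fold lower number from compound 2 to compound 3 (0.34 log units; beyond the scatter). The earlier change on the oxygen, a 1.0-fold lower number from compound 1 to compound 2 (0.01 log units; within the scatter), stayed within the scatter. No available measurement bears on the cause of this modest step. Still open, going by these compounds, is whether ethyl, a longer chain or a chain ending in an amine on this nitrogen would lower the number further. On these data alone, it is also open whether methyl gives a similar step when cyclobutyl sits on the oxygen.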